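A few compounds are considered here, and "the series" means these few. Any claim that something is new, unique, unknown or untested is made for them only; others in the source may bear on it.

Working notes on the series, which shares one core. Within the data shown here, in a functional assay on T98G cells (Homo sapiens) for inhibition, read by MTT assay, with a stated time of 72 h (a higher number here means a weaker inhibitor, a lower number a stronger inhibitor), compound 3 `CC1(C)CC(NC(=O)Nc2ccccc2Cl)c2cc(Br)ccc2O1` gives 11000 nM, the lowest of the three numbers so far. Compound 2 `CC1(C)CC(NC(=O)NCc2ccccc2)c2cc(Br)ccc2O1` gives 38000 nM. Compound 1 `CC1(C)CC(NC(=O)Nc2cccc(Cl)c2)c2cc(Br)ccc2O1` gives 67000 nM.

The next structure is compound 4 `CC1(C)CC(NC(=O)Nc2ccc(Cl)cc2)c2cc(Br)ccc2O1`, and the change is 4-chlorophenyl in place of 2-chlorophenyl on an amide-type nitrogen. Among the measured compounds shown here, no measured compound yet carries 4-chlorophenyl, so any forecast rests on indirect steps.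

For the measured compounds named here, the nearest precedent is 2-chlorophenyl in place of 3-chlorophenyl, which gave a 6.1-fold lower number from compound 1 to compound 3 (0.78 log units; beyond the scatter). Also relevant is 2-chlorophenyl in place of benzyl, which gave a 3.5-fold lower number from compound 2 to compound 3 (0.54 log units; beyond the scatter). By contrast, benzyl in place of 3-chlorophenyl gave a 1.8-fold lower number from compound 1 to compound 2 (0.25 log units; within the scatter). Among these three compounds, then, only the 2-chlorophenyl compound stands apart, and neither of the others goes against that.

Losing 2-chlorophenyl is therefore expected to raise the number in this assay, by a modest amount similar to the two steps into compound 3. The estimated step is a 2.7-fold higher number from compound 3 to compound 4 (0.44 log units; beyond the scatter). As far as these compounds go, the direction remains uncertain, since 4-chlorophenyl itself is untested. For compound 4 the expected value is 30000 nM, with an estimated range of 11000 nM to 80000 nM.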

Compound 4, half-maximal inhibitory concentration: 27000 nM
The estimate for compound 4 lay 1.1-fold (0.05 log units) above the measured number; low and high end bracket the measured number.
By their numbers in this assay, from the lowest: compound 3; then compounds 4, 2 and 1 (each within the scatter of the next, the first and the last beyond it).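

Moving the chlorine alone, with the same atoms, shifts the number in this assay in both directions (a 2.5-fold higher number from compound 3 to compound 4 (0.39 log units; beyond the scatter)) (a 2.5-fold lower number from compound 1 to compound 4 (0.39 log units; beyond the scatter)), so the three chlorophenyl compounds now lie beyond the scatter of one another, in the order 2-chlorophenyl, 4-chlorophenyl, 3-chlorophenyl from the lowest number. The low number of compound 3 therefore belongs, within these four compounds, to 2-chlorophenyl and not to chlorophenyl on the amide-type nitrogen as such, and its steps to all three others are beyond the scatter. The 4-chlorophenyl and benzyl groups cannot be told apart (a 1.4-fold lower number from compound 2 to compound 4 (0.15 log units; within the scatter)), which is within the scatter, so a chlorophenyl group as such gives no gain over benzyl here.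

The compounds shown leave open whether the gain with 2-chlorophenyl is specific to chlorine, since plain phenyl, 2-fluorophenyl, 2-methylphenyl and 2-methoxyphenyl have no values here, and it is equally open how an amine or a carboxylic acid on that phenyl ring would compare. Nothing available explains why the three chlorophenyl compounds differ in this way.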